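Clearance of Three Thiohydantoin Analogues in Mice

This account rests on a few compounds, and the source may have more. Where it says the series, first, only, none or still open, it means among the compounds named here.

Measured compounds:
- Compound 1, `N#Cc1ncc(N2C(=O)C3(CCC3)N(c3ccc(OC4CCNCC4)nc3)C2=S)cc1C(F)(F)F`: 15 mL/min/kg
- Compound 2, `N#Cc1ncc(N2C(=O)C3(CCC3)N(c3ccc(CN4CCNCC4)cc3)C2=S)cc1C(F)(F)F`: 18.2 mL/min/kg

In an ADME assay on the whole organism (Mus musculus, strain CD1) for pharmacokinetics, at a dose of 2 mg/kg by the intravenous route (on this read-out lower numbers stand for slow clearance and higher numbers for fast clearance), compound 1 gives 15 mL/min/kg and compound 2 gives 18.2 mL/min/kg. Compound 2 has the higher of the two numbers, but its nearest neighbour, compound 1, sits within the usual scatter of such measurements, so the two compounds cannot be told apart on this assay and no order between them is claimed.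

The next compound in the series is compound 3, `CN1CCC(Oc2ccc(N3C(=S)N(c4cnc(C#N)c(C(F)(F)F)c4)C(=O)C34CCC4)cc2)CC1`. It differs from compound 2 in one place: (1-methylpiperidin-4-yl)oxy in place of (piperazin-1-yl)methyl on an aromatic carbon. Going by the values given here, no pair of measured compounds shows the effect of this change, so its expected size must be judged from the two compounds that have been measured, which lie close together. On that basis the step from compound 2 to compound 3 is expected to be small, with no direction beyond the scatter: a 1.1-fold lower number from compound 2 to compound 3 (0.03 log units; within the scatter). In this assay compound 3 is therefore estimated at 17 mL/min/kg, with a plausible range from 9 mL/min/kg to 32 mL/min/kg.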

Compound 3, clearance: 4.12 mL/min/kg
Estimate against measurement, compound 3: 4.1-fold (0.62 log units) above; measured number outside the range, below it.
By their numbers in this assay, from the lowest: compound 3; then compounds 1 and 2 (each within the scatter of the next).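

Going by these compounds alone, the exchange at this position, on an aromatic carbon para to a large group, is not neutral in this assay: there is a 4.4-fold lower number from compound 2 to compound 3 (0.65 log units; beyond the scatter), a modest step beyond the scatter, and the earlier compounds offered no measured pair for this change. The group that leaves, (piperazin-1-yl)methyl, carries a hydrogen-bond donor and a ring with two hetero atoms, while the group that enters, (1-methylpiperidin-4-yl)oxy, has no donor and a ring with one hetero atom, so this single step alters several features at once and cannot be assigned to any one of them. Nothing measured here accounts for the step.

The compounds shown leave open which part of the exchange carries the step: the oxygen link, the ring itself or the methyl group on the ring nitrogen. On these data alone, it also remains unknown where a (piperidin-4-yl)oxy group without the methyl, a (4-methylpiperazin-1-yl)methyl group or a morpholine-bearing chain would fall at this position relative to compound 2 and compound 3.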